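This account rests on a few compounds, and the source may have more. Where it says the series, first, only, none or still open, it means among the compounds named here.

Measured so far in a functional assay on A549 cells (Homo sapiens) for cytotoxicity, read by MTT assay, with a stated time of 48 h; on this read-out higher numbers stand for weaker inhibition and lower numbers for stronger inhibition:
- compound 1 `COc1cc(-n2c(-c3ccc(Cl)cc3)cn(C(C)=O)c2=O)cc(OC)c1OC`: > 50000 nM (a limit)
- compound 2 `COc1cc(-n2c(-c3ccc([N+](=O)[O-])cc3)cn(C(C)=O)c2=O)cc(OC)c1OC`: 49600 nM
- compound 3 `COc1ccc(-c2cn(C(C)=O)c(=O)n2-c2cc(OC)c(OC)c(OC)c2)cc1OC`: > 50000 nM (a limit)

Compound 3 has no number, only the limit > 50000 nM. It shares that position with compound 1: the limit of > 50000 nM in this assay, at which 2 of the 3 values shown sit.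

Compound 4 `COc1ccc(-c2cn(C(C)=O)c(=O)n2-c2cc(OC)c(OC)c(OC)c2)cc1N` is compound 3 with one change: amino in place of methoxy on an aromatic carbon. Amino takes the place of a methoxy on an aromatic carbon, ortho to a methoxy group.

The measured steps give little guidance. a number no higher from compound 1 to compound 2 (the limit leaves the size open), a step that the two limits leave unreadable from compound 1 to compound 3 and a number no lower from compound 2 to compound 3 (the limit leaves the size open) each swap one whole aryl group for another, none exchanges methoxy for amino, and none has a readable size. With compound 3 at > 50000 nM, a readable step in this assay can only run towards lower numbers, so a drop is expected, though its size is poorly constrained and a second limit remains possible.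

The expected step is an at least 6.2-fold lower number from compound 3 to compound 4 (0.79 log units; beyond the scatter).

For compound 4 the estimate is 8000 nM, with an expected range of 200 nM to 50000 nM.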

Compound 4, half-maximal inhibitory concentration: 1100 nM
Compound 4: the middle estimate sits 7.3-fold (0.86 log units) above what was measured, and the stated range covers the measured number.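

In this assay, for the compounds shown here, an at least 45-fold lower number from compound 3 to compound 4 (1.65 log units; beyond the scatter) is the first readable step at this position, and it comes from exchanging a single methoxy for amino, ortho to a methoxy group, rather than swapping a whole aryl group. The 3-amino-4-methoxyphenyl group also gives a 45-fold lower number from compound 2 to compound 4 (1.65 log units; beyond the scatter) and an at least 45-fold lower number from compound 1 to compound 4 (1.65 log units; beyond the scatter), so a change on this aryl group can bring the series well clear of the top of its range. The steps from compound 1 and compound 3 start from limits and therefore fix only a minimum size: the limit of > 50000 nM in this assay, at which 2 of the 4 values shown sit.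

From the compounds shown here alone, whether a hydroxy, acetamido or dimethylamino group in the place of the amino would keep the lower number stays open. Also open, going by these compounds, is whether amino gives a similar step on other aryl groups around the shared core.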